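This account rests on a few compounds, and the source may have more. Where it says the series, first, only, none or still open, it means among the compounds named here.

Measured so far in an ADME assay on the whole organism (plasma) for pharmacokinetics, with Rattus norvegicus as the target, with a stated time of 6 h, at a dose of 10 mg/kg by the oral route; on this read-out lower numbers stand for lower exposure and higher numbers for higher exposure at the dose given:
Compound 1 `Nc1ncc(-c2nc3ccccc3s2)c(N[C@@H]2C[C@H](CO)[C@@H](O)[C@H]2O)n1` — compound 1 gives 149 ng.h/mL
Compound 2 `CCNc1nc(C)c(-c2nc3ccccc3s2)c(N[C@@H]2C[C@H](CO)[C@@H](O)[C@H]2O)n1` — compound 2 gives 2580 ng.h/mL
Compound 3 `COCCNc1nc(C)c(-c2nc3ccccc3s2)c(N[C@@H]2C[C@H](CO)[C@@H](O)[C@H]2O)n1` — compound 3 gives 2630 ng.h/mL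

Compound 3 holds the highest of the three numbers in this assay. Its nearest neighbour is compound 2, and that pair lies within the scatter; compound 1 stands far below it, beyond the scatter.

The next compound is compound 4 `Cc1nc(NCc2ccsc2)nc(N[C@@H]2C[C@H](CO)[C@@H](O)[C@H]2O)c1-c1nc2ccccc2s1`. Its change from compound 3 is thiophen-3-yl in place of methoxymethyl on a saturated chain carbon bound to a nitrogen on an aromatic ring.

Among the compounds with values here, only one measured step touches this part of the molecule: a 1.0-fold higher number from compound 2 to compound 3 (0.01 log units; within the scatter). That step shows that adding a methoxy to the chain did nothing beyond the scatter. Within the data shown here, no measured pair swaps the methoxymethyl for an aromatic ring such as thiophen-3-yl, so the record gives no direct guide to the size of the present step. Among the measured compounds shown here, since the single relevant step was flat, the expectation is a step of a 1.4-fold lower number from compound 3 to compound 4 (0.14 log units; within the scatter), that is, no clear movement, with a wide range to allow for the untested ring. Compound 4 is therefore estimated at 1900 ng.h/mL, between 500 ng.h/mL and 6500 ng.h/mL.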

Compound 4, area under the concentration-time curve: 96.7 ng.h/mL
Compound 4: middle estimate off by 20-fold (1.29 log units), on the high side; measured number outside the range, below it.
By their numbers in this assay, from the lowest: compounds 4 and 1 (each within the scatter of the next); then compounds 2 and 3 (each within the scatter of the next).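

In this assay the group on this saturated chain carbon turns out to matter a great deal: thiophen-3-yl in place of methoxymethyl gives a 27-fold lower number from compound 3 to compound 4 (1.43 log units; beyond the scatter) and thiophen-3-yl in place of methyl gives a 27-fold lower number from compound 2 to compound 4 (1.43 log units; beyond the scatter). The only earlier step at this place, a 1.0-fold higher number from compound 2 to compound 3 (0.01 log units; within the scatter), had shown that the chain could take a methoxy, and the present result shows that this tolerance does not reach a (thiophen-3-yl)methyl on the same nitrogen. Nothing available accounts for the loss of exposure.

The compounds shown leave open whether the fall follows the thiophen-3-yl itself or any ring at this place, which a phenyl or a cyclopropyl could separate. They also leave open whether a chain ending in an amine or a hydroxyl would keep the numbers of compound 2 and compound 3.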